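Closing the amine into a ring at the chain end

The source may report more compounds than this note shows. Statements on the series, on what has been measured and on what is new or still open speak of the compounds shown alone.

Compound 2 `CCN(CC)CCCOc1cc2ncnc(Nc3nc4ccc(C(=O)Nc5c(C)cccc5Cl)cc4s3)c2cc1OC` and compound 1 `COc1cc2c(Nc3nc4ccc(C(=O)Nc5c(C)cccc5Cl)cc4s3)ncnc2cc1OCCCN1CCCCC1C` share one core and differ only in the amine at the end of a three-carbon chain attached through an oxygen on an aromatic ring. Going by the values given here, in a functional assay on HCT-116 cells (Homo sapiens) for cytotoxicity, read by WST assay, with a stated time of 72 h (a lower number here means a stronger inhibitor, a higher number a weaker inhibitor), compound 2 gives 13200 nM, the highest of the two numbers so far; compound 1 gives 7200 nM. The step from one to the other, a 1.8-fold higher number from compound 1 to compound 2 (0.26 log units; within the scatter), stays inside the usual scatter, so the two amines look about the same on this reading.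

Compound 3 `COc1cc2c(Nc3nc4ccc(C(=O)Nc5c(C)cccc5Cl)cc4s3)ncnc2cc1OCCCN1CCCCC1` has not yet been measured. It differs from compound 2 by piperidin-1-yl in place of diethylamino on a saturated chain carbon, three bonds along the chain from an oxygen on an aromatic ring. Among the compounds with values here, this is close to the reverse of the one step already seen: a ring amine returning in place of the open diethylamino group. Since that step a 1.8-fold higher number from compound 1 to compound 2 (0.26 log units; within the scatter) was small, a step of similar size, if any, is expected here, pointing toward a somewhat lower number, and the expected change from compound 2 to compound 3 is a 1.7-fold lower number from compound 2 to compound 3 (0.22 log units; within the scatter). For compound 3 the estimate in this assay is 8000 nM, with a range from 3500 nM to 18000 nM.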

Compound 3, half-maximal inhibitory concentration: 23400 nM
The estimate for compound 3 lay 2.9-fold (0.47 log units) below the measured number, and the stated range ends below it.
By their numbers in this assay, from the lowest: compounds 1, 2 and 3 (each within the scatter of the next, the first and the last beyond it).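

In this assay, putting piperidin-1-yl in place of diethylamino gives a 1.8-fold higher number from compound 2 to compound 3 (0.25 log units; within the scatter) and so stays inside the scatter: on this reading, closing the open amine into a plain ring makes no difference that can be told apart from noise. The new compound also gives the first step here that clears the scatter, for with hydrogen in place of methyl on a saturated ring carbon the data show a 3.3-fold higher number from compound 1 to compound 3 (0.51 log units; beyond the scatter) and call that change modest, so a single methyl on the ring is the one edit among these compounds with a readable effect, while compound 2 cannot be ranked against either ring amine. Nothing measured here bears on why that methyl matters.

The compounds shown leave open whether the effect belongs to the methyl at this ring carbon in particular, or whether an ethyl group or a methyl on another ring carbon would read the same. They also leave open how other amines at the chain end, such as morpholin-4-yl or pyrrolidin-1-yl, or a shorter chain such as 2-(piperidin-1-yl)ethyl, would compare.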